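The source may hold more compounds than are shown below. What is called first, only, known or untested is meant among the compounds shown, and "the series" means these compounds.

Compound 1 `CC(C(=O)NCc1ccc(C(F)(F)F)nc1N1CCC(c2ccccc2)CC1)c1ccc(NS(C)(=O)=O)c(F)c1` and compound 2 `CC(C(=O)NCc1ccc(C(F)(F)F)nc1N1CCC(CN(C)C)CC1)c1ccc(NS(C)(=O)=O)c(F)c1` share one core and differ only in one group on a saturated ring carbon. In a functional assay on CHO-K1 cells for antagonist activity at transient receptor potential cation channel subfamily V member 1 (Homo sapiens), read by FLIPR (on this read-out higher numbers stand for weaker inhibition and lower numbers for stronger inhibition), compound 1 gives 0.6 nM, and compound 2 gives 2.1 nM. Of the two numbers available, compound 2 has the higher one, so it stands as the weaker of this pair, separated from compound 1 by a 3.5-fold higher number from compound 1 to compound 2 (0.54 log units; beyond the scatter). Compound 3 `CC(C(=O)NCc1ccc(C(F)(F)F)nc1N1CCN(C2CCCCC2)CC1)c1ccc(NS(C)(=O)=O)c(F)c1` is the next structure, not yet measured. It differs from compound 2 by 4-cyclohexylpiperazin-1-yl in place of 4-((dimethylamino)methyl)piperidin-1-yl on an aromatic carbon. Within the data shown here, the only step that bears on this change is the one from compound 1 to compound 2, which was modest in size; it shows that exchanging the group on that ring moves the number, but no measured step covers this exact exchange. Among the measured compounds shown here, compound 3 is therefore expected to land somewhere between the two known numbers, around 1.2 nM, with a likely range of 0.3 nM to 5 nM. This estimate for compound 3 means a step of a 1.8-fold lower number from compound 2 to compound 3 (0.24 log units; within the scatter), which is expected to be small.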

Compound 3, inhibition constant: 21.6 nM
Compound 3: middle estimate off by 18-fold (1.26 log units), on the low side; the measured number lies above the stated range.
By their numbers in this assay, from the lowest: compound 1; then compound 2; then compound 3.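

In this assay the group on the aromatic carbon next to the ring nitrogen proves far from interchangeable: 4-cyclohexylpiperazin-1-yl in place of 4-((dimethylamino)methyl)piperidin-1-yl gives a 10-fold higher number from compound 2 to compound 3 (1.01 log units; beyond the scatter) and is a large step, whereas the earlier change was modest. Set against 4-phenylpiperidin-1-yl, the same group gives a 36-fold higher number from compound 1 to compound 3 (1.56 log units; beyond the scatter) and leaves compound 3 with the highest number of the three, even though the groups leaving and entering in the step to compound 3 have equal counts of hydrogen-bond donors and acceptors. No measurement offered here accounts for these losses. As far as these compounds go, the step to compound 3 alters both the six-membered ring on the aromatic carbon and the group that ring carries, so the contribution of each stays open. A 4-cyclohexylpiperidin-1-yl or 4-phenylpiperazin-1-yl group would be needed to separate the two.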